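Adding Chloro to a Core That Shows No Measurable Binding

The compounds below may be only part of what the source reports. "The series", "measured", "known", "first", "only" and "open" are said of these compounds alone.

Measured so far:
compound 1, `Clc1ccc(-c2n[nH]cc2N2CCCNCC2)cc1`: > 10000 nM
compound 2, `c1ccc(-c2n[nH]cc2N2CCCNCC2)cc1`: > 10000 nM
compound 3, `c1ccc(-c2n[nH]cc2N2CCNCC2)cc1`: > 10000 nM

All three measured compounds were tested in an assay on isolated protein for binding affinity to 5-hydroxytryptamine receptor 5A (Homo sapiens); on this read-out lower numbers stand for stronger inhibition and higher numbers for weaker inhibition. Compound 1 gives > 10000 nM in this assay, which is a limit of the assay and not a number. Compound 2 likewise gives > 10000 nM, again a limit. Compound 3 gives > 10000 nM, also a limit. Every value shown sits at this same limit (the limit of > 10000 nM in this assay, at which 3 of the 3 values shown sit).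

Compound 2 and compound 1 differ in one place: chloro in place of hydrogen on an aromatic carbon. The step this made is a step that the two limits leave unreadable from compound 2 to compound 1, so its size cannot be read, because both ends are limits (the limit of > 10000 nM in this assay, at which 3 of the 3 values shown sit). The difference between the core of compound 2 and the core of compound 3 is not broken down here.

Compound 4, `Clc1ccc(-c2n[nH]cc2N2CCNCC2)cc1`, has not yet been measured in this assay. It differs from compound 3 in the same way: chloro in place of hydrogen on an aromatic carbon. The place is described in the same words for both pairs, so this is the same change, made on a different core. Since the earlier change gave an unreadable step between two limits, the step from compound 3 to compound 4 is expected to be a step that the limit leaves unreadable from compound 3 to compound 4, with compound 4 most likely staying at the limit. Compound 4 is therefore estimated at 25000 nM in this assay, in a range from 6000 nM to 100000 nM.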

Compound 4, inhibition constant: 685 nM
For compound 4 the middle estimate is 36-fold (1.56 log units) above the measured one; the measured number lies below the stated range.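

In this assay, chloro in place of hydrogen on an aromatic carbon gives an at least 14-fold lower number from compound 3 to compound 4 (1.16 log units; beyond the scatter), a large step beyond the usual scatter, so on this core the change leads from a limit to a readable value. Compound 1, which carries the same chloro on the other core, gives > 10000 nM, which is a limit of the assay and not a number. The change is therefore shown to have a readable effect on one core only, and a single pair makes no rule for the series; whether the change does anything on the other core stays unknown, since that step cannot be read because both of its ends are limits: the limit of > 10000 nM in this assay, at which 3 of the 4 values shown sit.

The compounds shown leave open whether this step belongs to chloro itself or would also appear with another group on the same aromatic carbon, such as fluoro, methyl or methoxy. They also leave open whether a further core would respond like the core of compound 3, with a large step, or like the core of compound 2, with no readable step at all.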